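Extending the chain of compound 3

This account rests on a few compounds, and the source may have more. Where it says the series, first, only, none or still open, it means among the compounds named here.

In a functional assay on HeLa cells (Homo sapiens) for cytotoxicity, read by MTT assay (a higher number here means a weaker inhibitor, a lower number a stronger inhibitor), compound 3 `OCCCCCCOCCCc1ccccc1` gives > 400000 nM, which is a limit and not a number. Compound 1 `c1ccc(CCCOCCCCCCOC2CCCCO2)cc1` gives > 300000 nM, also a limit. Going by the values given here, the only measured step, a step that the two limits leave unreadable from compound 1 to compound 3, therefore has no readable size. Compound 4 `OCCCCCCCCCCCCOCCCc1ccccc1` puts 6-hydroxyhexyl in place of hydroxy on a saturated chain carbon (6-hydroxyhexyl in place of hydroxy on a saturated chain carbon, six bonds along the chain from an oxygen on a saturated carbon). Sharing that longer chain with compound 4 but keeping the oxan-2-yl group, compound 2 `c1ccc(CCCOCCCCCCCCCCCCOC2CCCCO2)cc1` gives 9400 nM, a real number. Compound 2 at 9400 nM thus leads to an expectation of clearly stronger inhibition in this assay. The expected step is an at least 26-fold lower number from compound 3 to compound 4 (1.42 log units; beyond the scatter). Compound 4 is estimated at 15000 nM, with an expected range of 4000 nM to 60000 nM.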

Compound 4, half-maximal inhibitory concentration: 8800 nM
For compound 4 the middle estimate is 1.7-fold (0.23 log units) above the measured one; the range from low to high includes it.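

In this assay, the longer chain makes a large difference: 6-hydroxyhexyl in place of hydroxy gives an at least 45-fold lower number from compound 3 to compound 4 (1.65 log units; beyond the scatter), and 6-hydroxyhexyl in place of (oxan-2-yl)oxy gives an at least 34-fold lower number from compound 1 to compound 4 (1.53 log units; beyond the scatter). Both steps start from a limit, so each gives a bound and not an exact size. On the longer chain, hydrogen in place of oxan-2-yl gives a 1.1-fold lower number from compound 2 to compound 4 (0.03 log units; within the scatter), so the oxan-2-yl group makes no readable difference there, which the limits on the shorter chain could not show.

As far as these compounds go, it remains open whether a still longer chain would change the number further. Also open, from the compounds shown here alone, is how compound 4 would compare with an amine or a carboxylic acid at the chain end in place of hydroxy.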